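Swapping a Fluorophenyl Ring for a Hydroxyphenyl Ring

The source may hold more compounds than are shown below. What is called first, only, known or untested is meant among the compounds shown, and "the series" means these compounds.

Compound 1 `COc1cc(-c2nnc3n2NC(c2ccco2)C(C(=O)c2ccccc2F)S3)cc(OC)c1OC` carries a 2-fluorophenyl group on a carbonyl carbon. In a functional assay on HepG2 cells (Homo sapiens) for cytotoxicity, read by MTT assay, with a stated time of 48 h (on this read-out higher numbers stand for weaker inhibition and lower numbers for stronger inhibition), compound 1 reaches only the limit > 100000 nM, which is a limit of the measurement and not a number. Two measured relatives replace that group: compound 2 `COc1cc(-c2nnc3n2NC(c2ccco2)C(C(=O)c2cccs2)S3)cc(OC)c1OC` gives 64100 nM, and compound 3 `COc1cc(-c2nnc3n2NC(c2ccco2)C(C(=O)c2cccc4ccccc24)S3)cc(OC)c1OC` gives 33900 nM. The step of an at least 1.5-fold lower number from compound 1 to compound 2 (0.19 log units; that floor lies within the scatter) may be small, whereas an at least 2.9-fold lower number from compound 1 to compound 3 (0.46 log units; beyond the scatter) is clearly larger. Compound 4 `COc1cc(-c2nnc3n2NC(c2ccco2)C(C(=O)c2ccc(O)cc2)S3)cc(OC)c1OC` differs from compound 1 by 4-hydroxyphenyl in place of 2-fluorophenyl on a carbonyl carbon. For the measured compounds named here, no measured step trades a 2-fluorophenyl for a 4-hydroxyphenyl, so the change can only be judged against those two steps, both of which lowered the number. For compound 4 a modest lowering is therefore expected, an at least 1.2-fold lower number from compound 1 to compound 4 (0.09 log units; that floor lies within the scatter), though the limit may be reached again. Compound 4 is estimated at 80000 nM, between 30000 nM and 200000 nM.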

Compound 4, half-maximal inhibitory concentration: > 100000 nM
Compound 4: a limit, no number (the forecaster's own chance of this, stated with the estimate: 45%); at least 1.2-fold (0.09 log units) between middle value and limit.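

Putting 4-hydroxyphenyl on this carbonyl carbon gives an at least 2.9-fold higher number from compound 3 to compound 4 (0.46 log units; beyond the scatter), so this six-membered ring does not keep the lower number seen with naphthalen-1-yl. Against thiophen-2-yl the same change gives an at least 1.5-fold higher number from compound 2 to compound 4 (0.19 log units; that floor lies within the scatter), a floor too small to show a real difference on its own. The step between compound 1 and compound 4 cannot be read, because both sit at a limit and not at a number: the limit of > 100000 nM in this assay, at which 2 of the 4 values shown sit.

Going by these compounds, whether 4-aminophenyl or 4-carboxyphenyl on the same carbonyl carbon would give a number rather than a limit remains open. On these data alone, how far apart compound 1 and compound 4 truly lie also remains open.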